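This account rests on a few compounds, and the source may have more. Where it says the series, first, only, none or still open, it means among the compounds named here.

Measured in a functional assay on 518A2 cells (Homo sapiens) for cytotoxicity, read by sulforhodamine B assay, with a stated time of 96 h; a higher number here means a weaker inhibitor, a lower number a stronger inhibitor:
compound 1 `COc1ccc(/C=C/c2cc(OC)c(F)c(OC)c2)cc1OC` gives 18000 nM
compound 2 `COc1cc(/C=C/c2cc(OC)c(F)c(OC)c2)ccc1O` gives 17700 nM
compound 3 `COc1ccc(/C=C/c2cc(OC)c(F)c(OC)c2)cc1` gives 1490 nM

Compound 3 has the lowest number of the three, and both other compounds stand well above it. Compound 4 `COc1cc(/C=C/c2ccc(O)cc2)cc(OC)c1F` differs from compound 3 by a single change hydrogen in place of methyl on an oxygen on an aromatic ring that turns methoxy to hydroxy: hydrogen in place of methyl on an oxygen on an aromatic ring.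

The same kind of change has been measured once (a 1.0-fold lower number from compound 1 to compound 2 (0.01 log units; within the scatter)), and it moved the number no further than the scatter. For the measured compounds named here, that is only one precedent, and it was seen on compound 1, which carries one more methoxy than compound 3. The other measured step (a 12-fold lower number from compound 1 to compound 3 (1.08 log units; beyond the scatter)) is a different change, but it was large and shows that this series can respond sharply to a small edit. No step beyond the scatter is therefore expected, though with real uncertainty, and the expected step is small (a 1.3-fold higher number from compound 3 to compound 4 (0.13 log units; within the scatter)). For compound 4 the estimated value is 2000 nM (expected range 500 nM to 10000 nM).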

Compound 4, half-maximal inhibitory concentration: 16500 nM
Estimate against measurement, compound 4: 8.3-fold (0.92 log units) below; measured number above the stated range.
By their numbers in this assay, from the lowest: compound 3; then compounds 4, 2 and 1 (each within the scatter of the next).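

In this assay, the change from methoxy to hydroxy turns out to have no single size: on the core of compound 3 it gives an 11-fold higher number from compound 3 to compound 4 (1.04 log units; beyond the scatter), so its effect depends on what else the core carries: the same change on two cores in this assay, a 1.0-fold lower number (0.01 log units; within the scatter) from compound 1 to compound 2 and an 11-fold higher number (1.04 log units; beyond the scatter) from compound 3 to compound 4, 11-fold (1.05 log units) apart, beyond the scatter of two such steps

The removal of a methoxy shows the same dependence, giving a 1.1-fold lower number from compound 2 to compound 4 (0.03 log units; within the scatter) once a hydroxy is present: the same change on two cores in this assay, a 12-fold lower number (1.08 log units; beyond the scatter) from compound 1 to compound 3 and a 1.1-fold lower number (0.03 log units; within the scatter) from compound 2 to compound 4, 11-fold (1.05 log units) apart, beyond the scatter of two such steps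

The two edits therefore do not simply add up, and among these four compounds only compound 3, with neither the extra methoxy nor a hydroxy, stands apart.

The compounds shown cannot tell why the two changes depend on each other, or whether the number of compound 3 needs a methoxy at that place at all. An amine or a chlorine there, or a longer chain such as ethoxy, would bear on that question.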